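Trimethoxyphenyl replacing chlorophenyl on the saturated ring carbon

A few compounds are considered here, and "the series" means these few. Any claim that something is new, unique, unknown or untested is made for them only; others in the source may bear on it.

Measured so far in a functional assay on SR cells (Homo sapiens) for antiproliferative activity, with a stated time of 48 h; a lower number here means a stronger inhibitor of growth, a higher number a weaker inhibitor of growth:
- compound 1 `Cc1cc(O)c(C2=NN(c3ccc(S(N)(=O)=O)cc3)C(c3ccccc3Cl)C2)cc1Cl`: 2970 nM
- compound 2 `COc1ccc(C2CC(c3cc(Cl)c(C)cc3O)=NN2c2ccc(S(N)(=O)=O)cc2)cc1OC`: 2820 nM

Among the compounds with values here, only two compounds have numbers, and compound 1 is not separated from compound 2 by them: the step of a 1.1-fold lower number from compound 1 to compound 2 (0.02 log units; within the scatter) lies within the scatter, so neither compound can be called the stronger inhibitor of growth. The shared core of compound 1 carries a 2-chlorophenyl on a saturated ring carbon, and compound 2 carries a 3,4-dimethoxyphenyl at the same place; exchanging one for the other left this assay essentially unchanged.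

Compound 3 `COc1ccc(C2CC(c3cc(Cl)c(C)cc3O)=NN2c2ccc(S(N)(=O)=O)cc2)c(OC)c1OC` takes the same route one step further: 2,3,4-trimethoxyphenyl in place of 2-chlorophenyl on a saturated ring carbon. Within the data shown here, the only measured step that bears on this change is the one from compound 1 to compound 2, which introduced two methoxy groups on the same ring and produced no movement beyond the scatter. Nothing measured speaks for a larger effect from a third methoxy group. The expectation is therefore a step of about a 1.1-fold lower number from compound 1 to compound 3 (0.04 log units; within the scatter), that is, none beyond the scatter. Compound 3 is estimated at 2700 nM in this assay, within a range of 1200 nM to 6000 nM.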

Compound 3, concentration for 50% growth inhibition: 2470 nM
Beside the measured number, compound 3's estimate is 1.1-fold (0.04 log units) above it; low and high end bracket the measured number.
By their numbers in this assay, from the lowest: compounds 3, 2 and 1 (each within the scatter of the next).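

Moving to the 2,3,4-trimethoxyphenyl group gives a 1.2-fold lower number from compound 1 to compound 3 (0.08 log units; within the scatter) in this assay and so extends what compound 2 showed: the 2-chlorophenyl on this saturated ring carbon can give way to an aryl group with three methoxy substituents and no chlorine without the read-out leaving the scatter. Within the data shown here, the single-point change, methoxy in place of hydrogen on an aromatic carbon, gives a 1.1-fold lower number from compound 2 to compound 3 (0.06 log units; within the scatter) and is the first reading of one methoxy group on its own, since the earlier step brought in two methoxy groups and removed the chlorine at once. No supporting data accompany these numbers that could account for the flat result. The three compounds leave open whether any group at this place can move the number beyond the scatter, for example a phenyl ring bearing a carboxylic acid or a dimethylamino group, or a saturated alkyl chain in place of the aryl ring. They also leave open whether the 4-sulfamoylphenyl group and the 5-chloro-2-hydroxy-4-methylphenyl group, constant in all three, carry more weight in this assay than this position does.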